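Sec-butyl at the chain carbon: compound 4 in the series

The compounds below may be only part of what the source reports. "The series", "measured", "known", "first", "only" and "open" are said of these compounds alone.

Measured compounds in a functional assay for inhibition, read by spectrophotometry, with a stated time of 20 min, tested at 3 mg/mL; a higher number here means a stronger effect of the compound at the concentration tested, a lower number a weaker effect:
compound 1 `CC(=O)c1ccc(NC(=O)CN(C(=O)c2ccccc2)S(=O)(=O)c2ccc(C)cc2)cc1`: 18.2%
compound 2 `CCC(C)C(C(=O)Nc1ccc(C(C)=O)cc1)N(C(=O)c1ccccc1)S(=O)(=O)c1ccc([N+](=O)[O-])cc1`: 42.1%
compound 3 `CC(=O)c1ccc(NC(=O)CN(C(=O)c2ccccc2)S(=O)(=O)c2ccccc2)cc1`: 40.7%

Compound 3 stands second highest of the three numbers in this assay. Among the compounds with values here, its nearest neighbour is compound 2, whose value lies within the scatter of that of compound 3; the furthest is compound 1, the one step recorded being a number 22.5 percentage points higher from compound 1 to compound 3 (beyond the scatter).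

Compound 4 `CCC(C)C(C(=O)Nc1ccc(C(C)=O)cc1)N(C(=O)c1ccccc1)S(=O)(=O)c1ccccc1` is to be measured. It differs from compound 3 by sec-butyl in place of hydrogen on a saturated chain carbon bound to an amide-type nitrogen and a carbonyl carbon. Within the data shown here, no measured step bears on this change: the only step, a number 22.5 percentage points higher from compound 1 to compound 3 (beyond the scatter), concerns the aromatic carbon. Compound 2 carries the same sec-butyl group, but differs from compound 3 in two places, and the two values sit within the scatter of each other. No step beyond the scatter is therefore expected, a number 1.3 percentage points higher from compound 3 to compound 4 (within the scatter).

Compound 4 is estimated at 42%, range 25% to 60%.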

Compound 4, a percentage reported as inhibition, at one concentration (the size of the read-out at that concentration, not a potency): 14.3%
The estimate for compound 4 lay 27.7 percentage points above the measured number; the measured number lies below the stated range.
By their numbers in this assay, from the lowest: compounds 4 and 1 (each within the scatter of the next); then compounds 3 and 2 (each within the scatter of the next).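

In this assay, the saturated chain carbon bound to an amide-type nitrogen and a carbonyl carbon is sensitive to substitution: sec-butyl in place of hydrogen gives a number 26.4 percentage points lower from compound 3 to compound 4 (beyond the scatter). With sec-butyl held at that carbon, the aromatic carbon also matters, with hydrogen in place of nitro giving a number 27.8 percentage points lower from compound 2 to compound 4 (beyond the scatter). Nothing available explains either step.

Going by these compounds, the effect of sec-butyl with nitro on the aromatic carbon remains open, since compound 2 has no partner carrying hydrogen at the chain carbon. Also open, on these data alone, is how an isopropyl group or a carboxylic acid at the chain carbon would read.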